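The compounds below may be only part of what the source reports. "The series", "measured", "known", "first", "only" and "open" are said of these compounds alone.

Measured compounds:
- Compound 1, `Cc1cc(C(F)(F)F)cc(OCc2c(-c3c(Cl)cccc3Cl)noc2C(C)C)n1`: "not active" (no number reported) in a functional assay on HEK293 cells for agonist activity at Bile acid receptor (Homo sapiens); on this read-out higher numbers stand for an effect only at larger amounts of compound and lower numbers for an effect already at smaller amounts
- Compound 2, `CC(C)c1onc(-c2c(Cl)cccc2Cl)c1COc1ccc(N(C)Cc2cccc(C(=O)O)c2)c(C(F)(F)F)n1`: 80 nM
- Compound 3, `CN(Cc1cccc(C(=O)O)c1)c1ccc(OCc2c(-c3c(Cl)cccc3Cl)noc2C2CC2)nc1C(F)(F)F`: 9 nM

Compound 1 has no number in this assay, only the word given. Among the two compounds with numbers, compound 3 stands lowest, and the only step measured so far, an 8.9-fold lower number from compound 2 to compound 3 (0.95 log units; beyond the scatter), separates it from compound 2.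

Compound 4, `CC(Oc1ccc(C(=O)O)cc1)c1ccc(OCc2c(-c3c(Cl)cccc3Cl)noc2C2CC2)nc1C(F)(F)F`, differs from compound 3 in a different place: 1-(4-carboxyphenoxy)ethyl in place of (3-carboxybenzyl)(methyl)amino on an aromatic carbon. For the measured compounds named here, the measured step from compound 2 to compound 3 touched the cyclopropyl end of the shared core, not the carboxylic-acid-bearing side chain, so no measured step bears on this change. The acid group is kept, but its carrier changes from an amine-linked to an ether-linked chain with the acid moved to a new position on its ring. With no guide from the data, a modest loss is expected for compound 4, an expected step of a 3.3-fold higher number from compound 3 to compound 4 (0.52 log units; beyond the scatter), giving an estimate of 30 nM with a range from 5 nM to 200 nM.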

Compound 4, half-maximal effective concentration: 189 nM
Beside the measured number, compound 4's estimate is 6.3-fold (0.80 log units) below it; the measured number falls inside the stated range.
By their numbers in this assay, from the lowest: compound 3; then compound 2; then compound 4.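

Compound 3 and compound 4 differ only in the side chain at this position, and in this assay this change gives a 21-fold higher number from compound 3 to compound 4 (1.32 log units; beyond the scatter). For the compounds shown here, this is the first measured change at this position, and it shows that the number responds strongly to the structure of the side chain. The (3-carboxybenzyl)(methyl)amino and 1-(4-carboxyphenoxy)ethyl groups have the same counts of heavy atoms, hydrogen-bond donors and hydrogen-bond acceptors, and each holds one carbon-only aromatic ring, so these counts alone do not settle the outcome here. Nothing available explains the size of this step.

The swap alters the chain's atoms and the place of the acid on its ring together, so the compounds shown cannot say which alteration matters most. Going by these compounds, how a tetrazole or a primary amide in place of the carboxylic acid would fare at this position also remains open.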